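Methyl to methoxy on a shared core, weighed twice

This account rests on a few compounds, and the source may have more. Where it says the series, first, only, none or still open, it means among the compounds named here.

Measured compounds:
compound 1, `Cc1ccc(C(=O)NNC(=S)Nc2csc(-c3ccccc3)c2)cc1`, 40000 nM
compound 2, `COc1ccc(C(=O)NNC(=S)Nc2csc(-c3ccccc3)c2)cc1`, 36000 nM
compound 3, `Cc1ccc(-c2nnc(Nc3csc(-c4ccccc4)c3)s2)cc1`, "not determined" (no result reported)

In a functional assay on A549 cells (Homo sapiens) for inhibition, read by colorimetric assay and MTT assay, with a stated time of 72 h (a higher number here means a weaker inhibitor, a lower number a stronger inhibitor), compound 1 gives 40000 nM and compound 2 gives 36000 nM. The change between them is methoxy in place of methyl on an aromatic carbon and it made a 1.1-fold lower number from compound 1 to compound 2 (0.05 log units; within the scatter). Compound 3 carries a different core, and the difference between the two cores is not broken down here. No number was obtained for compound 3 in this assay. Among the measured compounds shown here, compound 4, `COc1ccc(-c2nnc(Nc3csc(-c4ccccc4)c3)s2)cc1`, is the unmeasured partner of compound 3, and it differs from compound 3 by methoxy in place of methyl on an aromatic carbon, the same change as the one from compound 1 to compound 2, at the same kind of place. With no value for compound 3 to stand on, the expectation for compound 4 in this assay rests only on the size of the earlier step and on the weak level of compound 1 and compound 2, so a wide range is expected: compound 4 is estimated at 40000 nM, with an expected span from 8000 nM to 200000 nM.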

Compound 4, half-maximal inhibitory concentration: 8000 nM
Estimate against measurement, compound 4: 5.0-fold (0.70 log units) above, and the stated range covers the measured number.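

In this assay, among the compounds shown here, compound 4 gives 8000 nM but compound 3 has no number, so no step from compound 3 to compound 4 can be read. The compounds shown leave open whether methoxy in place of methyl acts on this core as it does on the core of compound 1. No measured evidence bears on the value of compound 4.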